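A few compounds are considered here, and "the series" means these few. Any claim that something is new, unique, unknown or untested is made for them only; others in the source may bear on it.

Measured so far:
compound 1, `CS(=O)(=O)c1ccc(-c2cnc3[nH]cc(-c4nnc(-c5ccccc5)o4)c(=O)c3c2)cc1`, 27.2% in a functional assay on HCT-116 cells (Homo sapiens) for positive allosteric modulation, read by MTT assay, with stated times of 24 h and 48 h, tested at 2.5 uM; a higher number here means more inhibition of growth at the concentration tested, a lower number less inhibition of growth
compound 2, `CS(=O)(=O)c1ccc(-c2cnc3[nH]cc(-c4nnc(-c5ccc(Cl)cc5)o4)c(=O)c3c2)cc1`, 24.9% in this assay

Within the data shown here, compound 2 stands lowest of the two numbers, and its nearest neighbour is compound 1, whose number is higher by a margin that is within the scatter; the one step between them, a number 2.3 percentage points lower from compound 1 to compound 2 (within the scatter), is likewise within the scatter, so the two compounds cannot be told apart on these numbers.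

Compound 3, `O=c1c(-c2nnc(-c3ccc(Cl)cc3)o2)c[nH]c2ncc(-c3ccccc3)cc12`, has not yet been measured. It differs from compound 2 by hydrogen in place of methylsulfonyl on an aromatic carbon, on an aromatic carbon of a six-membered aromatic ring of carbon only, para to a large group. Among the measured compounds shown here, no measured step touches this part of the molecule: the only step known, from compound 1 to compound 2, changes a different ring. There is therefore no basis in the numbers for expecting a step in this assay beyond the scatter, and the estimate for compound 3 is a modest drop, a number 4.9 percentage points lower from compound 2 to compound 3 (within the scatter), giving an expected value of 20%, between 5% and 35%.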

Compound 3, percent growth inhibition at one concentration: 29.8%
For compound 3 the middle estimate is 9.8 percentage points below the measured one; the measured number falls inside the stated range.
By their numbers in this assay, from the lowest: compounds 2, 1 and 3 (each within the scatter of the next).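

Removing the methylsulfonyl group, so that 4-(methylsulfonyl)phenyl becomes phenyl, gives a number 4.9 percentage points higher from compound 2 to compound 3 (within the scatter) in this assay and is the first change shown at this position. With the chloro group held constant, the methylsulfonyl group is therefore not shown to be needed for the growth inhibition seen here, since hydrogen at the same aromatic carbon gives a number that cannot be told apart from that of compound 2. Nothing available bears on why this position tolerates the change.

The compounds shown leave open whether any group at this position can move the number beyond the scatter, and an amine or a carboxylic acid there would test this. They also leave open whether this result holds without the chloro group on the other ring.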